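A few compounds are considered here, and "the series" means these few. Any claim that something is new, unique, unknown or untested is made for them only; others in the source may bear on it.

Measured compounds in a functional assay on MCF7 cells (Homo sapiens) for cytotoxicity, read by MTT assay, with a stated time of 48 h; on this read-out lower numbers stand for stronger inhibition and higher numbers for weaker inhibition:
compound 1, `COc1cc(-c2nnc3n2NC(c2ccco2)C(C(=O)c2ccccc2F)S3)cc(OC)c1OC`: 94800 nM
compound 2, `COc1cc(-c2nnc3n2NC(c2ccco2)C(C(=O)c2ccc(-c4ccccc4)cc2)S3)cc(OC)c1OC`: > 100000 nM

In this assay compound 1 gives 94800 nM. For compound 2 the read-out is a limit of the assay and not a number, > 100000 nM, that is, (the limit of > 100000 nM in this assay, at which 1 of the 2 values shown sits). The one step between them, an at least 1.0-fold higher number from compound 1 to compound 2 (0.02 log units; that floor lies within the scatter), lies within the scatter, so on the numbers shown compound 2 stands together with compound 1 at the weak end of the series, with no order between the two.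

Compound 3, `COc1cccc(C(=O)C2Sc3nnc(-c4cc(OC)c(OC)c(OC)c4)n3NC2c2ccco2)c1`, differs from compound 2 in one place: 3-methoxyphenyl in place of 4-phenylphenyl on a carbonyl carbon. Within the data shown here, the only measured step that touches this position is the aryl swap from compound 1 to compound 2, and it stayed within the scatter. The change to compound 3 is a swap of the same kind on the same carbonyl carbon, so no step beyond the scatter is expected in this assay in either direction, and a weak result near the level of compound 1 is the working assumption.

Compound 3 is therefore estimated at 90000 nM in this assay, with a range from 40000 nM to 200000 nM. That estimate corresponds to an expected step of an at least 1.1-fold lower number from compound 2 to compound 3 (0.04 log units; that floor lies within the scatter).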

Compound 3, half-maximal inhibitory concentration: > 100000 nM
Compound 3: only a limit was reported; the forecaster's own chance of this, stated with the estimate: 40%; middle value at least 1.1-fold (0.04 log units) from the limit.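

In this assay compound 3 also ends at a limit of the assay, > 100000 nM, so a third aryl group on this carbonyl carbon fails to give a value inside the range of the assay: the limit of > 100000 nM in this assay, at which 2 of the 3 values shown sit.

Against 2-fluorophenyl, 3-methoxyphenyl gives an at least 1.0-fold higher number from compound 1 to compound 3 (0.02 log units; that floor lies within the scatter), so this second aryl swap at the position also shows no change that can be told from the scatter. The step between the two limit compounds, compound 2 and compound 3, cannot be read, but going from the two rings of 4-phenylphenyl to the single ring of 3-methoxyphenyl does not bring the read-out off the limit.

Going by these compounds, how far compound 2 and compound 3 lie past the limit stays unknown, so no order can be set among the three compounds. On these data alone, whether an aryl ring carrying an amine or a carboxylic acid on this carbonyl carbon would give a clearly lower number stays open, as does whether any change elsewhere on the shared core would do so.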